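Swapping chloro for trifluoromethyl on the phenyl ring

The compounds below may be only part of what the source reports. "The series", "measured", "known", "first", "only" and "open" are said of these compounds alone.

Compound 2 `Oc1cc(C(F)(F)F)ccc1-c1nc(-c2ccccc2O)n(-c2ccccc2Cl)n1` gives 70.1% in a functional assay on PC-12 cells (Rattus norvegicus) for cytotoxicity, read by MTT assay, with stated times of 2 h and 24 h, tested at 1 uM (a higher number here means a stronger effect of the compound at the concentration tested, a lower number a weaker effect), and stands alongside compound 1 `CCc1ccc(-n2nc(-c3ccc(C(F)(F)F)cc3O)nc2-c2ccccc2O)cc1`, which gives 64.4%; the step of a number 5.7 percentage points higher from compound 1 to compound 2 (within the scatter) lies within the scatter. Compound 3 `Oc1cc(C(F)(F)F)ccc1-c1nc(-c2ccccc2O)n(-c2ccccc2C(F)(F)F)n1` differs from compound 2 by trifluoromethyl in place of chloro on an aromatic carbon. Among the measured compounds shown here, no measured step concerns this exchange. For the measured compounds named here, the only step seen, replacing one group on the aromatic nitrogen by another, was small. A step of a number 1.1 percentage points lower from compound 2 to compound 3 (within the scatter) is therefore expected for compound 3 in this assay, nothing beyond the scatter. Compound 3 is estimated at 69%, between 54% and 84%.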

Compound 3, a percentage reported as activity, at one concentration (the size of the read-out at that concentration, not a potency): 71%
The estimate for compound 3 lay 2 percentage points below the measured number; low and high end bracket the measured number.
By their numbers in this assay, from the lowest: compounds 1, 2 and 3 (each within the scatter of the next).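

A step of a number 0.9 percentage points higher from compound 2 to compound 3 (within the scatter) comes with trifluoromethyl in place of chloro on this aromatic carbon, so this assay does not tell these two groups apart, even though the entering group has more heavy atoms. Likewise, a number 6.6 percentage points higher from compound 1 to compound 3 (within the scatter) goes with 2-(trifluoromethyl)phenyl in place of 4-ethylphenyl on the aromatic nitrogen. Nothing available gives a reason for these small steps. Still open, as far as these compounds go, is whether an amine or a carboxylic acid on this same carbon would shift the number beyond the scatter.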